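The source may report more compounds than this note shows. Statements on the series, on what has been measured and on what is new or still open speak of the compounds shown alone.

Compound 1, `COc1ccc(Nc2c(-c3ccc(F)cc3)c(C)nn2-c2ccccc2C)c(C(=O)O)c1`: 1.39 nM
Compound 2, `COc1ccc(Nc2c(-c3ccc(F)c(F)c3)c(C)nn2-c2ccccc2C)c(C(=O)O)c1`: 294 nM
Compound 3, `COc1ccc(-c2c(C)nn(-c3ccccc3C)c2Nc2ccc(OC)cc2C(=O)O)cc1`: 306 nM

All three were tested in a functional assay for antagonist activity at adenosine receptor A1 (Homo sapiens), read by cAMP accumulation; on this read-out lower numbers stand for stronger inhibition and higher numbers for weaker inhibition. Compound 3 gives the highest number of the three, yet a 1.0-fold higher number from compound 2 to compound 3 (0.02 log units; within the scatter), so compound 3 and compound 2 cannot be told apart; only compound 1 stands clearly lower, as a 220-fold higher number from compound 1 to compound 3 (2.34 log units; beyond the scatter) shows.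

Compound 4, `COc1ccc(Nc2c(-c3ccc(OC)c(OC)c3)c(C)nn2-c2ccccc2C)c(C(=O)O)c1`, is not yet measured. It differs from compound 3 in one place: methoxy in place of hydrogen on an aromatic carbon. The measured step that most resembles this one puts a further group on a ring that already carries one, in going from compound 1 to compound 2, where a 210-fold higher number from compound 1 to compound 2 (2.33 log units; beyond the scatter). The other two steps swap one group for another rather than adding one, so they guide less. Among the measured compounds shown here, on that single comparison a higher number is expected for compound 4, though a change as large as the one between compound 1 and compound 2 is not assured.

For compound 4 the estimate in this assay is 1500 nM, with a range from 300 nM to 8000 nM. This corresponds to an expected step of a 4.9-fold higher number from compound 3 to compound 4 (0.69 log units; beyond the scatter).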

Compound 4, half-maximal inhibitory concentration: 233 nM
Compound 4: the middle estimate sits 6.4-fold (0.81 log units) above what was measured; measured number below the stated range.
By their numbers in this assay, from the lowest: compound 1; then compounds 4, 2 and 3 (each within the scatter of the next).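

In this assay, the second methoxy of the 3,4-dimethoxyphenyl group leaves compound 4 indistinguishable from its 4-methoxyphenyl parent, with a 1.3-fold lower number from compound 3 to compound 4 (0.12 log units; within the scatter) as the step. Its 3,4-difluorophenyl counterpart is just as close, at a 1.3-fold lower number from compound 2 to compound 4 (0.10 log units; within the scatter) on this comparison, while a 170-fold higher number from compound 1 to compound 4 (2.22 log units; beyond the scatter) keeps the 4-fluorophenyl compound alone among the four at a clearly lower number. A further group on this ring therefore has no single effect: the added fluoro gave a 210-fold higher number from compound 1 to compound 2 (2.33 log units; beyond the scatter) as its step, whereas the added methoxy stays within the scatter.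

Going by these compounds, whether an amine or a hydroxyl on the 4-fluorophenyl ring would keep the low number of compound 1 remains open. Nothing shown explains why the added fluoro and the added methoxy part ways.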